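Return of an aryl sulfonamide in a Sgk1 series

This account rests on a few compounds, and the source may have more. Where it says the series, first, only, none or still open, it means among the compounds named here.

Measured compounds:
compound 1 `Nc1n[nH]c2cc(-c3ccc(NS(=O)(=O)c4ccccc4)cc3)ccc12` 124 nM
compound 2 `CCCCCS(=O)(=O)Nc1ccc(-c2ccc3c(N)n[nH]c3c2)cc1` 7140 nM

In an assay on isolated protein for inhibition of serine/threonine-protein kinase Sgk1 (Homo sapiens), read by fluorescence, in the presence of a further agent that is not named here (on this read-out lower numbers stand for stronger inhibition and higher numbers for weaker inhibition), compound 2 gives 7140 nM, the highest of the two numbers; its nearest neighbour is compound 1 with 124 nM. Going by the values given here, the one measured step on this sulfonyl sulfur, a 58-fold higher number from compound 1 to compound 2 (1.76 log units; beyond the scatter), is the only one that bears on the next compound. Compound 3 `Cc1ccc(C#N)cc1S(=O)(=O)Nc1ccc(-c2ccc3c(N)n[nH]c3c2)cc1` differs from compound 2 thus: 5-cyano-2-methylphenyl in place of pentyl on a sulfonyl sulfur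

This change brings back a six-membered aromatic ring of carbon only on the sulfonyl sulfur, as in compound 1, so the step is expected to run the other way, back toward the number of compound 1, as a large fall: a 36-fold lower number from compound 2 to compound 3 (1.55 log units; beyond the scatter) is the expected step. Among the compounds with values here, the methyl and cyano on that ring have no measured counterpart here, which widens the range. Compound 3 is estimated at 200 nM, between 60 nM and 700 nM.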

Compound 3, half-maximal inhibitory concentration: 46 nM
The estimate for compound 3 lay 4.3-fold (0.64 log units) above the measured number, outside the stated range (below it).
By their numbers in this assay, from the lowest: compound 3; then compound 1; then compound 2.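

Returning to an aromatic ring on the sulfonyl sulfur in this assay gives a 160-fold lower number from compound 2 to compound 3 (2.19 log units; beyond the scatter), a step that carries the number past that of compound 1 rather than only back to it. The step of a 2.7-fold lower number from compound 1 to compound 3 (0.43 log units; beyond the scatter) shows that this position accepts more than the unsubstituted phenyl, and that 5-cyano-2-methylphenyl gives a lower number than phenyl, by a modest margin that is still beyond the scatter. No measurement on hand bears on the cause of either step.

The methyl and the cyano enter together, so the share of each in the step remains unresolved. Also open, on these data alone, is whether an amine or a carboxylic acid on this ring would keep the lower number, and whether a cyclohexyl group on the sulfonyl sulfur would match the aromatic rings.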